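Swapping One Five-Membered Ring for Another on a Shared Core

The source may report more compounds than this note shows. Statements on the series, on what has been measured and on what is new or still open speak of the compounds shown alone.

Measured so far:
- compound 1, `Cc1ccc(-c2nc(N)c3cc(C(C)c4ccccc4)sc3n2)o1`: 439 nM
- compound 2, `Nc1nc(-c2ccc(C3CC3)o2)nc2sc(Cc3ccccc3)cc12`: 861 nM

Both compounds were tested in a functional assay on CHO-K1 cells for antagonist activity at adenosine receptor A1 (Homo sapiens), read by a beta-galactosidase reporter and cAMP accumulation, with stated times of 15 min and 6 h; on this read-out higher numbers stand for weaker inhibition and lower numbers for stronger inhibition. In this assay compound 1 gives 439 nM, and compound 2 gives 861 nM. Among the compounds with values here, compound 2 carries the higher of the two numbers, but compound 1 is its only neighbour, and the gap between them lies within the usual scatter of repeated measurements, so the two cannot be told apart. The two compounds also differ from each other in more than one place, so this pair says nothing about any single structural change.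

Compound 3, `Cc1nc(-c2nc(N)c3cc(Cc4ccccc4)sc3n2)cs1`, has not yet been measured. It differs from compound 2 in a single place: 2-methyl-1,3-thiazol-4-yl in place of 5-cyclopropylfuran-2-yl on an aromatic carbon. Within the data shown here, no measured pair in this set shows this exact change, so there is no step to lean on. The exchange keeps an aromatic five-membered ring in the same position, and the expectation is a small shift, if any, with a slight lean toward a higher number, but nothing that can be confidently placed beyond the scatter.

Compound 3 is therefore estimated to give about 1200 nM in this assay, with a plausible range from 300 nM to 5000 nM. That estimate corresponds to an expected step of a 1.4-fold higher number from compound 2 to compound 3 (0.14 log units; within the scatter).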

Compound 3, inhibition constant: 263 nM
Beside the measured number, compound 3's estimate is 4.6-fold (0.66 log units) above it; measured number below the stated range.
By their numbers in this assay, from the lowest: compounds 3, 1 and 2 (each within the scatter of the next, the first and the last beyond it).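

Within the data shown here, exchanging 5-cyclopropylfuran-2-yl for 2-methyl-1,3-thiazol-4-yl on the aromatic carbon between two ring nitrogen atoms gives, in this assay, a 3.3-fold lower number from compound 2 to compound 3 (0.52 log units; beyond the scatter), the first single-place change in this set and one that can be read. It shows that the read-out responds to what sits at this position, even when one five-membered aromatic ring simply replaces another. The change alters several things at once, since the entering group has fewer heavy atoms, a second ring hetero atom, an extra hydrogen-bond acceptor and no three-membered ring, and no measurement shown here separates these differences or explains the shift.

From the compounds shown here alone, it remains open whether the lower number comes with the thiazole ring itself, its methyl group or the loss of the cyclopropyl group, a question that 2-methyl-1,3-thiazol-4-yl and 5-cyclopropylfuran-2-yl alone cannot settle. Going by these compounds, it is also open how this position would respond to a group of a different kind, such as a plain phenyl ring, an amine or a carboxylic acid.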